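Cytotoxicity limits and the step to compound 3

A few compounds are considered here, and "the series" means these few. Any claim that something is new, unique, unknown or untested is made for them only; others in the source may bear on it.

Compound 1 `COc1ccc(C(=O)Nc2cc(-c3ccccn3)n[nH]2)cc1`: > 40300 nM
Compound 2 `N#Cc1ccc(OC2CCN(C(=O)Nc3cc(-c4ccccn4)n[nH]3)CC2)cc1`: > 64000 nM

Both compounds were tested in an ADME assay on cells (Peritoneal macrophage cell, Mus musculus) for cytotoxicity, read by fluorescence and resazurin assay, with a stated time of 3 days; on this read-out lower numbers stand for higher toxicity in this test and higher numbers for lower toxicity in this test. There compound 1 gives > 40300 nM, which is a limit and not a number. Compound 2 gives > 64000 nM, which is again a limit and not a number. Among the compounds with values here, the place of compound 2 on this scale is therefore known only as a limit, and the same is true of the one other compound measured.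

Compound 3 `O=C(Nc1cc(-c2ccccn2)n[nH]1)N1CCC(c2cccc(Cl)c2)CC1` has not yet been measured. It carries 3-chlorophenyl in place of 4-cyanophenoxy on a saturated ring carbon. Within the data shown here, no measured pair shows what a change of this kind does in this assay, so any expectation is loose. A modest move towards lower numbers is expected, and another limit would be no surprise. The expected change is an at least 1.8-fold lower number from compound 2 to compound 3 (0.26 log units; that floor lies within the scatter). For compound 3 the estimated value is 35000 nM, with an expected range from 10000 nM to 90000 nM.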

Compound 3, half-maximal cytotoxic concentration: > 22000 nM
Compound 3: a limit, no number; the forecaster's own chance of this, stated with the estimate: 55%; the middle value lies beyond the limit too.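

Compound 2 and compound 3 are both known in this assay only as limits, and the step between them cannot be read. The compounds shown leave open whether 3-chlorophenyl in place of 4-cyanophenoxy on a saturated ring carbon changes the read-out at all, and where the actual half-maximal cytotoxic concentration of any of the three compounds lies.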